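The compounds below may be only part of what the source reports. "The series", "measured", "known", "first", "only" and "open" are said of these compounds alone.

Measured so far in a functional assay for agonist activity at G protein-coupled receptor 88 (Homo sapiens), read by HTRF and cAMP accumulation; a lower number here means that less compound is needed, a higher number that more compound is needed for the effect:
Compound 1 `CC(C)C[C@H](N)CN(C(=O)[C@@H]1C[C@H]1c1ccccc1)c1ccc(-c2ccccc2)cc1` gives 880 nM.
Compound 2 `CC(C)CCCN(C(=O)[C@@H]1C[C@H]1c1ccccc1)c1ccc(-c2ccccc2)cc1` gives > 100 nM, which is a limit of the assay and not a number.
Compound 3 `CC(C)(N)CN(C(=O)[C@@H]1C[C@H]1c1ccccc1)c1ccc(-c2ccccc2)cc1` gives 1.4 nM.

Among the numbers shown in this assay, compound 1 stands highest. Its nearest neighbour is compound 3, reached by the step of a 630-fold lower number from compound 1 to compound 3 (2.80 log units; beyond the scatter), a large one. The step that the limit leaves unreadable from compound 1 to compound 2 cannot be read because of the limit of > 100 nM in this assay, at which 1 of the 3 values shown sits. The step of an at least 71-fold lower number from compound 2 to compound 3 (1.85 log units; beyond the scatter) is likewise large.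

Compound 4 `CC(C)C[C@H](N)CN(C(=O)[C@@H]1C[C@H]1c1ccccc1)c1ccc(-c2ccccc2F)cc1` is not yet measured. It differs from compound 1 by fluoro in place of hydrogen on an aromatic carbon.

All three measured steps concern the group on the saturated chain carbon bound to the amide-type nitrogen, either swapping that group or removing its amino. Among the measured compounds shown here, none of them touches the six-membered aromatic ring of carbon only, so no measured step bears directly on the change from compound 1 to compound 4. With nothing in the measured data pointing either way, the expectation is a step of no size beyond the scatter: no change at the digits printed from compound 1 to compound 4 (within the scatter). Compound 4 is therefore estimated in this assay at 880 nM, expected to fall between 250 nM and 3000 nM.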

Compound 4, half-maximal effective concentration: 1600 nM
For compound 4 the middle estimate is 1.8-fold (0.26 log units) below the measured one, within the range that was stated.
By their numbers in this assay, from the lowest: compound 3; then compounds 1 and 4 (each within the scatter of the next).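

Among the compounds shown here, changing phenyl to 2-fluorophenyl is the first measured change on this aromatic ring, as all the earlier steps concerned the chain group on the amide-type nitrogen, and in this assay it gives a 1.8-fold higher number from compound 1 to compound 4 (0.26 log units; within the scatter) for this single added fluoro. Compound 1 and compound 4 therefore cannot be told apart in this assay, so on this background a fluoro ortho to a large group makes no readable difference, unlike the chain change in a 630-fold lower number from compound 1 to compound 3 (2.80 log units; beyond the scatter) on the same background. The compounds shown offer no explanation for why this fluoro leaves the result within the scatter.

As far as these compounds go, it remains open whether the same fluoro would also stay within the scatter on the background of compound 3, which gives 1.4 nM and so offers a much lower number against which a change could be read. Also open, from the compounds shown here alone, is how a different group in this place, such as chloro, methoxy or nitrile, would read, and how a fluoro would read on the other carbons of this ring.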